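The compounds below may be only part of what the source reports. "The series", "measured", "known", "first", "only" and "open" are said of these compounds alone.

Working notes on the series. Compound 1 `O=C1NCCc2nc(C#Cc3ccccc3F)sc21` in an assay on HEK293 cells for positive allosteric modulation of metabotropic glutamate receptor 5 (Homo sapiens), read by FLIPR, with a stated time of 1 h (a lower number here means that less compound is needed, a higher number that more compound is needed for the effect), gives 1500 nM. Compound 2 `CN1CCc2nc(C#Cc3cccc(F)c3)sc2C1` reaches only the limit of this assay, > 10000 nM. Compound 3 `CC(C)CN1CCc2nc(C#Cc3ccccc3)sc2C1` likewise reaches only the limit of this assay, > 10000 nM. Compound 3 thus stands at the limit of > 10000 nM in this assay, at which 2 of the 3 values shown sit, and has no number of its own in this assay. Going by the values given here, of the three values shown, only that of compound 1 is a number.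

Compound 4 `O=C(C1CC1)N1CCc2nc(C#Cc3ccccc3)sc2C1` differs from compound 3 in one place: cyclopropylcarbonyl in place of isobutyl on an amine nitrogen in a ring. Among the compounds with values here, no step between two measured compounds covers this change, so its size cannot be read from the measured compounds. Within the data shown here, the single number in this assay, from compound 1 at 1500 nM, leaves room for compound 4 to come into the measurable range. Compound 4 may also stay beyond the measurable range of this assay. The step from compound 3 to compound 4 is expected to be an at least 3.3-fold lower number from compound 3 to compound 4 (0.52 log units; beyond the scatter), toward lower values. Compound 4 is estimated at 3000 nM, between 600 nM and 15000 nM.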

Compound 4, half-maximal effective concentration: > 10000 nM
Compound 4 ended at the assay's limit; the forecaster's own chance of this, stated with the estimate: 40%; at least 3.3-fold (0.52 log units) between middle value and limit.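

Going by these compounds alone, no step from compound 3 to compound 4 can be read, as each has only a limit and no number of its own: the limit of > 10000 nM in this assay, at which 3 of the 4 values shown sit. Left open is whether cyclopropylcarbonyl or isobutyl on an amine nitrogen in a ring gives the lower number in this assay.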